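This account rests on a few compounds, and the source may have more. Where it says the series, first, only, none or still open, it means among the compounds named here.

In a functional assay on MDA-MB-468 cells (Homo sapiens) for antiproliferative activity, read by MTT assay, with a stated time of 48 h (a higher number here means a weaker inhibitor, a lower number a stronger inhibitor), compound 3 (`CC(=O)Nc1cc2cnc(NCCN(C)C)cc2n(C)c1=O`), with methyl on a carbonyl carbon, reads > 100000 nM, which is a limit of the assay and not a number. Compound 1 (`CN(C)CCNc1cc2c(cn1)cc(NC(=O)c1cc3ccccc3s1)c(=O)n2C`), with 1-benzothiophen-2-yl at that place, gives 3570 nM. Compound 2 (`COc1cccc(C(=O)Nc2cc3cnc(NCCN(C)C)cc3n(C)c2=O)c1`), with 3-methoxyphenyl there, gives 17400 nM. Compound 3 is thus the weakest of the three measured compounds.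

Compound 4 (`CN(C)CCNc1cc2c(cn1)cc(NC(=O)c1ccc(Cl)cc1)c(=O)n2C`) has 4-chlorophenyl in place of methyl on a carbonyl carbon. A ring therefore enters where compound 3 has none.

Within the data shown here, two measured steps bear on this change when read backwards, as each puts methyl where a ring-bearing group stood. The first is large: an at least 28-fold higher number from compound 1 to compound 3 (1.44 log units; beyond the scatter). The second is at least modest: an at least 5.7-fold higher number from compound 2 to compound 3 (0.75 log units; beyond the scatter). The choice of ring also counts, as shown by a modest step: a 4.9-fold higher number from compound 1 to compound 2 (0.69 log units; beyond the scatter). Compound 4 carries a substituted phenyl, as compound 2 does, so the closest guide is compound 2 at 17400 nM.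

On these data alone, the step expected in this assay is an at least 9.0-fold lower number from compound 3 to compound 4 (0.95 log units; beyond the scatter), a clear move towards a stronger inhibitor, though its exact size stays open with a limit at one end. For compound 4 the estimated value is 11000 nM, with an expected range from 3500 nM to 35000 nM.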

Compound 4, half-maximal inhibitory concentration: 1640 nM
Compound 4: the middle estimate sits 6.7-fold (0.83 log units) above what was measured, and the stated range ends above it.
By their numbers in this assay, from the lowest: compound 4; then compound 1; then compound 2. At a limit, above all of these: compound 3.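

Compound 3 reads at a limit of the assay and not a number, so an at least 60-fold lower number from compound 3 to compound 4 (1.78 log units; beyond the scatter) in this assay fixes only one end of the gain from replacing methyl with a ring: the limit of > 100000 nM in this assay, at which 1 of the 4 values shown sits. What is new is how much the choice of substituted phenyl counts, since an 11-fold lower number from compound 2 to compound 4 (1.03 log units; beyond the scatter) separates two rings that each carry one substituent, so a phenyl ring alone does not set the reading at this carbonyl carbon. The 4-chlorophenyl group also goes past the larger ring system, with a 2.2-fold lower number from compound 1 to compound 4 (0.34 log units; beyond the scatter), which makes compound 4 the strongest of the four and shows that 1-benzothiophen-2-yl is not needed for the best reading among them.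

Compound 2 and compound 4 differ in both the substituent and its place on the ring, so these compounds cannot say which of the two matters; 3-chlorophenyl and 4-methoxyphenyl would separate them. On these data alone, it also stays open how this position would respond to a ring carrying an amine or a carboxylic acid, or to a longer chain in place of the ring.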